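Butylsulfanyl in place of pentylamino on a shared core

The compounds below may be only part of what the source reports. "The series", "measured", "known", "first", "only" and "open" are said of these compounds alone.

Measured compounds:
compound 1, `CCSc1nc(N)c2nc(O)n(Cc3ccccc3)c2n1`: 0.1 uM
compound 2, `CCCCCNc1nc(N)c2nc(O)n(Cc3ccccc3)c2n1`: 0.1 uM

In a functional assay (spleen, spleen) for activation, with Mus musculus as the target (a lower number here means that less compound is needed, a higher number that more compound is needed for the effect), compound 1 gives 0.1 uM, and compound 2 gives 0.1 uM. The step between them, no change at the digits printed from compound 1 to compound 2 (within the scatter), shows that the change from ethylsulfanyl to pentylamino on that aromatic carbon left the read-out where it was. Compound 2 therefore stands level with compound 1 at the digits shown.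

Compound 3, `CCCCSc1nc(N)c2nc(O)n(Cc3ccccc3)c2n1`, differs from compound 2 in one place: butylsulfanyl in place of pentylamino on an aromatic carbon. Among the compounds with values here, the only measured step that bears on this change is no change at the digits printed from compound 1 to compound 2 (within the scatter), which was flat. Since compound 3 returns to a sulfanyl chain of the kind seen in compound 1, the step of no change at the digits printed from compound 2 to compound 3 (within the scatter) is expected to stay within the scatter. Compound 3 is estimated at 0.1 uM, with a range from 0.03 uM to 0.3 uM.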

Compound 3, minimum effective concentration: 0.01 uM
Compound 3: the middle estimate sits 10-fold (1.00 log units) above what was measured; the measured number lies below the stated range.
By their numbers in this assay, from the lowest: compound 3; then compounds 1 and 2 (each within the scatter of the next).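

In this assay this position turns out to be responsive, which the flat step between the first two compounds did not reveal: butylsulfanyl in place of pentylamino gives a 10-fold lower number from compound 2 to compound 3 (1.00 log units; beyond the scatter) and lengthening the sulfanyl chain from ethyl to butyl gives a 10-fold lower number from compound 1 to compound 3 (1.00 log units; beyond the scatter) on the shared core. A sulfanyl chain alone therefore does not set the read-out, as the ethylsulfanyl and butylsulfanyl groups are separated by a step beyond the scatter. No available evidence accounts for this difference.

The compounds shown leave open whether pentylsulfanyl or a longer sulfanyl chain would lower the number further, and where between ethylsulfanyl and butylsulfanyl the drop sets in. They also leave open how butylamino would compare, which would separate the linking atom from the chain, since compound 3 differs from compound 2 in both.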